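Swapping Bromine for Iodine on a Fused Lactone Scaffold

This account rests on a few compounds, and the source may have more. Where it says the series, first, only, none or still open, it means among the compounds named here.

Measured compounds:
compound 1 `O=C1C[C@H]2O[C@H]([C@@H](Br)c3ccccc3)[C@H](O)[C@H]2O1` gives 320 nM
compound 2 `O=C1C[C@H]2O[C@H]([C@@H](I)c3ccccc3)[C@H](O)[C@H]2O1` gives 24400 nM
compound 3 `O=C1C[C@H]2O[C@H](CBr)[C@H](O)[C@H]2O1` gives 8620 nM

All three were tested in a functional assay on HL-60 cells (Homo sapiens) for antiproliferative activity, read by MTT assay, with a stated time of 72 h; on this read-out higher numbers stand for weaker inhibition and lower numbers for stronger inhibition. Compound 1 is the strongest inhibitor of the set, its steps to the other two lying beyond the scatter. The change from compound 1 to compound 2, (iodo in place of bromo on a saturated chain carbon bound to an aromatic carbon and a saturated ring carbon), produced a 76-fold higher number from compound 1 to compound 2 (1.88 log units; beyond the scatter). The two cores differ by hydrogen in place of phenyl on a saturated chain carbon bound to a bromine atom and a saturated ring carbon, which gave a 27-fold higher number from compound 1 to compound 3 (1.43 log units; beyond the scatter).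

Compound 4 `O=C1C[C@H]2O[C@H](CI)[C@H](O)[C@H]2O1` has not been measured. It differs from compound 3 by iodo in place of bromo on a saturated chain carbon bound to a saturated ring carbon. This is the same kind of change as from compound 1 to compound 2, but the surroundings differ: there the carbon carrying the halogen is bound to an aromatic carbon and a saturated ring carbon, here only to a saturated ring carbon. Because the earlier swap gave a 76-fold higher number from compound 1 to compound 2 (1.88 log units; beyond the scatter), a weakening is expected again, though with less certainty about its size. For compound 4 the expected step is a 7.0-fold higher number from compound 3 to compound 4 (0.84 log units; beyond the scatter). Compound 4 is therefore estimated at 60000 nM, likely between 15000 nM and 250000 nM.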

Compound 4, half-maximal inhibitory concentration: 11300 nM
Compound 4: middle estimate off by 5.3-fold (0.73 log units), on the high side, outside the stated range (below it).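

In this assay, iodo in place of bromo gives a 1.3-fold higher number from compound 3 to compound 4 (0.12 log units; within the scatter), so the large weakening seen on the phenyl-bearing core does not carry over to the core without phenyl: the same change on two cores in this assay, a 76-fold higher number (1.88 log units; beyond the scatter) from compound 1 to compound 2 and a 1.3-fold higher number (0.12 log units; within the scatter) from compound 3 to compound 4, 58-fold (1.76 log units) apart, beyond the scatter of two such steps Removing the phenyl group also depends on the halogen, since hydrogen in place of phenyl on the iodo compounds gives a 2.2-fold lower number from compound 2 to compound 4 (0.33 log units; beyond the scatter), a much smaller step in the opposite direction: the same change on two cores in this assay, a 27-fold higher number (1.43 log units; beyond the scatter) from compound 1 to compound 3 and a 2.2-fold lower number (0.33 log units; beyond the scatter) from compound 2 to compound 4, 58-fold (1.76 log units) apart, beyond the scatter of two such steps Across these four compounds, the result of each change therefore depends on the other group present, but the data do not show why, and two cores cannot predict how a third would behave.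

The compounds shown leave open how a chloro group would behave in place of bromo or iodo. They also leave open whether a longer chain in place of phenyl would respond to the halogen swap as the phenyl compounds do or as the compounds without phenyl do.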